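The source may hold more compounds than are shown below. What is called first, only, known or untested is meant among the compounds shown, and "the series" means these compounds.

Measured compounds in an ADME assay on a cell-free system (plasma, Homo sapiens) for metabolic stability, read by LC-MS, with a stated time of 60 min, at 37 degrees C, tested at 50 uM; on this read-out higher numbers stand for a more stable compound and lower numbers for a less stable compound:

Compound 1, `CCC(CC)C(=O)OCOC(=O)C1=C(S[C@@H]2CN[C@H](C(=O)Nc3cccc(C(=O)O)c3)C2)[C@H](C)[C@@H]2[C@@H]([C@@H](C)O)C(=O)N12`, gives 82%.
Compound 2, `C[C@@H](O)[C@H]1C(=O)N2C(C(=O)OCOC(=O)OC3CCCCC3)=C(S[C@@H]3CN[C@H](C(=O)Nc4cccc(C(=O)O)c4)C3)[C@H](C)[C@H]12`, gives 46%.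
Compound 3, `C[C@@H](O)[C@H]1C(=O)N2C(C(=O)OCOC(=O)OC3CCCCC3)=C(S[C@@H]3CN[C@H](C(=O)Nc4cccc(C(=O)OCOC(=O)OC5CCCCC5)c4)C3)[C@H](C)[C@H]12`, gives 96%.

Compound 2 stands lowest of the three numbers in this assay ; its nearest neighbour is compound 1, and compound 3 lies furthest from it, both steps beyond the scatter.

Compound 4, `C[C@@H](O)[C@H]1C(=O)N2C(C(=O)OCC(F)(F)F)=C(S[C@@H]3CN[C@H](C(=O)Nc4cccc(C(=O)O)c4)C3)[C@H](C)[C@H]12`, is not yet measured. It differs from compound 2 as follows: trifluoromethyl in place of (cyclohexyloxycarbonyl)oxy on a saturated chain carbon bound to an oxygen next to a carbonyl group.

Within the data shown here, two measured steps touch this region of the series. The step of a number 36 percentage points lower from compound 1 to compound 2 (beyond the scatter) alters the group on the carbonyl carbon of the same ester and moves the number by a large amount. The step of a number 50 percentage points higher from compound 2 to compound 3 (beyond the scatter) adds a ((cyclohexyloxycarbonyl)oxy)methyl group on an oxygen at a different position and is also large. Among the measured compounds shown here, neither step is the same exchange as the one from compound 2 to compound 4, so the direction cannot be read off directly; what the step from compound 1 to compound 2 does show is that changes at this ester move the read-out well beyond the scatter. A step of similar size is therefore expected, most likely upward, given that compound 2 is already the lowest number and compound 1 with a different group at this ester gives 82%.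

For compound 4 the estimated value in this assay is 78%, with a range from 50% to 98%. This estimate corresponds to an expected step of a number 32 percentage points higher from compound 2 to compound 4 (beyond the scatter).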

Compound 4, percent of the compound remaining: 80%
Beside the measured number, compound 4's estimate is 2 percentage points below it, within the range that was stated.
By their numbers in this assay, from the lowest: compound 2; then compounds 4 and 1 (each within the scatter of the next); then compound 3.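

In this assay, the exchange of (cyclohexyloxycarbonyl)oxy for trifluoromethyl on the saturated chain carbon bound to an oxygen next to a carbonyl group gives a number 34 percentage points higher from compound 2 to compound 4 (beyond the scatter), so a group with no ring and no hydrogen-bond acceptors at this place does not bring the low number of compound 2. With a number 2 percentage points lower from compound 1 to compound 4 (within the scatter), the read-out does not separate trifluoromethyl from ((pentan-3-yl)carbonyl)oxy at this place, so among compounds 1, 2 and 4 the low number goes with (cyclohexyloxycarbonyl)oxy alone and not with the position as a whole. No measurement shown here explains the difference between these groups.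

An ethyl ester at this place would be needed to tell the contribution of the fluorine atoms from the simple loss of (cyclohexyloxycarbonyl)oxy, and the compounds shown leave that comparison open. Also open, on these data alone, is how a longer chain such as 3,3,3-trifluoropropyl, or a chain ending in an amine, would read in this assay on the shared core.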